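A few compounds are considered here, and "the series" means these few. Any claim that something is new, unique, unknown or untested is made for them only; others in the source may bear on it.

Measured compounds:
- compound 1, `COc1cccc(Oc2ccc(NC(=O)C3CC3)cc2)c1`: 99 nM
- compound 2, `COCC(=O)Nc1ccc(Oc2cccc(OC)c2)cc1`: 180 nM

Compound 1 and compound 2 share one core and differ only at the group on the carbonyl carbon. In an assay on isolated protein for binding affinity to melatonin receptor type 1A (Homo sapiens) (on this read-out higher numbers stand for weaker inhibition and lower numbers for stronger inhibition), compound 1 gives 99 nM and compound 2 gives 180 nM; the step of a 1.8-fold higher number from compound 1 to compound 2 (0.26 log units; within the scatter) lies within the scatter, so the two numbers are indistinguishable. Compound 2 holds the higher of the two numbers shown, with compound 1 as its only neighbour.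

Compound 3, `CCNC(=O)Nc1ccc(Oc2cccc(OC)c2)cc1`, is not yet measured. From compound 2 it differs by ethylamino in place of methoxymethyl on a carbonyl carbon, so the ((methoxymethyl)carbonyl)amino group becomes an (ethylcarbamoyl)amino group. Among the compounds with values here, no measured step covers this change; the one step available, a 1.8-fold higher number from compound 1 to compound 2 (0.26 log units; within the scatter), concerns a different exchange at the same carbonyl carbon and was within the scatter. That single step gives no sign of a large effect from varying this position, but it is only one data point.

For compound 3 the expected step is a 1.4-fold higher number from compound 2 to compound 3 (0.14 log units; within the scatter), no more than the scatter. The estimate for compound 3 in this assay is 250 nM, with a range from 80 nM to 800 nM.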

Compound 3, inhibition constant: > 500 nM
Compound 3 ended at the assay's limit; the forecaster's own chance of this, stated with the estimate: 3%; at least 2.0-fold (0.30 log units) between middle value and limit.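

In this assay compound 3 reads > 500 nM, which is a limit of the assay and not a number: the limit of > 500 nM in this assay, at which 1 of the 3 values shown sits.

Within the data shown here, the group on the carbonyl carbon is therefore not indifferent to change: ethylamino in place of methoxymethyl gives an at least 2.7-fold higher number from compound 2 to compound 3 (0.44 log units; beyond the scatter), and ethylamino in place of cyclopropyl gives an at least 5.0-fold higher number from compound 1 to compound 3 (0.70 log units; beyond the scatter), whereas the only earlier step at this carbon, a 1.8-fold higher number from compound 1 to compound 2 (0.26 log units; within the scatter), stayed within the scatter. Methoxymethyl and ethylamino have the same heavy-atom count, so that count does not separate compound 2 from compound 3, and the exchange instead replaces an oxygen with a nitrogen and adds a hydrogen-bond donor while removing a hydrogen-bond acceptor.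

Going by these compounds, compound 3 gives only a limit, so the full size of both steps stays open, and one exchange cannot show whether the nitrogen on the carbonyl carbon, its hydrogen or the ethyl chain carries the step. An ethoxy group, a dimethylamino group or a longer chain on the same carbonyl carbon would bear on that question.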